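A few compounds are considered here, and "the series" means these few. Any claim that something is new, unique, unknown or untested is made for them only; others in the source may bear on it.

Working notes on the aminothiophene series

Among the compounds with values here, the three measured members share one core and differ only in the aryl group attached to it. Compound 1 `CC(C)(C)Cc1c(-c2cc(F)ccc2F)sc(N)c1C(=O)c1ccc(Cl)cc1` carries a 2,5-difluorophenyl and in an assay on CHO cells for displacement of a labelled ligand from adenosine receptor A3 (Homo sapiens), read by scintillation counting, tested at 10 uM (on this read-out higher numbers stand for more inhibition at the one concentration tested (going by the name of the read-out) and lower numbers for less inhibition), compound 1 gives 1%. Compound 2 `COc1ccccc1-c1sc(N)c(C(=O)c2ccc(Cl)cc2)c1CC(C)(C)C` carries a 2-methoxyphenyl and in this assay compound 2 gives 1%. The step of no change at the digits printed from compound 1 to compound 2 (within the scatter) therefore shows that swapping one aryl substituent pattern for another left the read-out where it was. Compound 3 `COCCOc1ccc(-c2sc(N)c(C(=O)c3ccc(Cl)cc3)c2CC(C)(C)C)cc1`, with a 2-methoxyethoxy on the aryl ring, gives 1% in this assay; it stands level with compound 1 and compound 2, the three values lying within the scatter of one another.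

Compound 4 `COc1ccc(-c2sc(N)c(C(=O)c3ccc(Cl)cc3)c2CC(C)(C)C)cc1` is the next member. Its difference from compound 3 is hydrogen in place of methoxymethyl on a saturated chain carbon bound to an oxygen on an aromatic ring. This is again a change confined to the aryl substituent, the same region altered between compound 1 and compound 2, where the step was within the scatter. Within the data shown here, no measured step bears on anything else. The expectation is therefore a step of no change at the digits printed from compound 3 to compound 4 (within the scatter), that is, none beyond the scatter, and compound 4 is estimated at 1% in this assay, with a range from -8% to 12%.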

Compound 4, a percentage reported as inhibition, at one concentration (the size of the read-out at that concentration, not a potency): 2%
For compound 4 the middle estimate is 1 percentage points below the measured one; low and high end bracket the measured number.
By their numbers in this assay, from the lowest: compounds 1, 2, 3 and 4 (each within the scatter of the next).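

Cutting 2-methoxyethoxy back to methoxy, on a saturated chain carbon bound to an oxygen on an aromatic ring, gives a number 1 percentage points higher from compound 3 to compound 4 (within the scatter) in this assay, so losing the methoxymethyl leaves this read-out within the scatter. The 4-methoxyphenyl of compound 4, taken in place of 2-methoxyphenyl, gives a number 1 percentage points higher from compound 2 to compound 4 (within the scatter) and, taken in place of 2,5-difluorophenyl, gives a number 1 percentage points higher from compound 1 to compound 4 (within the scatter) as well, so neither moving the methoxy nor exchanging the two fluorines for it separates these compounds in this assay. No measurement at hand offers any explanation for this flat result.

The compounds shown leave open whether any group on this aryl position can lift inhibition beyond the scatter, for instance a carboxylic acid or a dimethylamino group at the end of the chain on the oxygen. They also leave open whether changes elsewhere on the shared core, such as an amide in place of the free amine, would do so, since every step shown is confined to the aryl group.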